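Working notes: from trifluoromethyl to fluoro

A few compounds are considered here, and "the series" means these few. Any claim that something is new, unique, unknown or untested is made for them only; others in the source may bear on it.

Measured in a functional assay on KBVIN cells (Homo sapiens) for antiproliferative activity, read by sulforhodamine B assay, with a stated time of 3 days; on this read-out lower numbers stand for an effect already at smaller amounts and higher numbers for an effect only at larger amounts of compound:
- compound 1 `CCC1=C(O)c2c(oc(-c3ccc(C(C)C)cc3)cc2=O)C(CC)(CC)C1=O`: 1.08 uM
- compound 2 `CCC1=C(O)c2c(oc(-c3ccc(O)cc3)cc2=O)C(CC)(CC)C1=O`: 20.6 uM
- compound 3 `CCC1=C(O)c2c(oc(-c3cccc(C(F)(F)F)c3)cc2=O)C(CC)(CC)C1=O`: 5.42 uM

Compound 3 holds the middle of the three numbers, with compound 1 lower and compound 2 higher. Compound 4 `CCC1=C(O)c2c(oc(-c3cccc(F)c3)cc2=O)C(CC)(CC)C1=O` differs from it by fluoro in place of trifluoromethyl on an aromatic carbon. For the measured compounds named here, the only measured single-place step is a 19-fold higher number from compound 1 to compound 2 (1.28 log units; beyond the scatter). Going by the values given here, it swaps other groups, so it shows only that such a swap can matter in this assay. Among the compounds with values here, no measured step covers this change, and only a small shift towards a higher number is expected, probably not beyond the scatter. The expected step is a 1.5-fold higher number from compound 3 to compound 4 (0.17 log units; within the scatter). Compound 4 is estimated at 8 uM, with an expected range of 3 uM to 20 uM.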

Compound 4, concentration for half-maximal effect: 3.09 uM
Compound 4: middle estimate off by 2.6-fold (0.41 log units), on the high side, and the stated range covers the measured number.
By their numbers in this assay, from the lowest: compound 1; then compounds 4 and 3 (each within the scatter of the next); then compound 2.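

In this assay, for the compounds shown here, fluoro in place of trifluoromethyl on an aromatic carbon gives the first measured step at this place (a 1.8-fold lower number from compound 3 to compound 4 (0.24 log units; within the scatter)), so the two groups are not told apart here. Compound 4 also stands clear of both para-free comparisons in the set, with one step from the 4-hydroxyphenyl compound (a 6.7-fold lower number from compound 2 to compound 4 (0.82 log units; beyond the scatter)) and one from the 4-isopropylphenyl compound (a 2.9-fold higher number from compound 1 to compound 4 (0.46 log units; beyond the scatter)). Nothing available explains these steps. Open, on these data alone, is whether an amine or a carboxylic acid on this carbon would stay level with fluoro and trifluoromethyl.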